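Trimethoxyphenyl in place of chlorophenyl on the imidazolone ring

This account rests on a few compounds, and the source may have more. Where it says the series, first, only, none or still open, it means among the compounds named here.

Measured compounds:
compound 1 `COc1cc(/C=C/C(=O)c2cccc(-n3cc(-c4ccc(Cl)cc4)[nH]c3=O)c2)cc(OC)c1OC` with 3850 nM
compound 2 `COc1ccc(-c2cn(-c3cccc(C(=O)/C=C/c4ccc(O)c(OC)c4)c3)c(=O)[nH]2)cc1` with 3150 nM

Of the compounds shown here, two share a chalcone-bearing core and have been measured in a functional assay on HCT-15 cells (Homo sapiens) for inhibition; a higher number here means a weaker inhibitor of growth, a lower number a stronger inhibitor of growth. Compound 1, `COc1cc(/C=C/C(=O)c2cccc(-n3cc(-c4ccc(Cl)cc4)[nH]c3=O)c2)cc(OC)c1OC`, gives 3850 nM in this assay. Compound 2, `COc1ccc(-c2cn(-c3cccc(C(=O)/C=C/c4ccc(O)c(OC)c4)c3)c(=O)[nH]2)cc1`, gives 3150 nM in this assay. Going by the values given here, the two values lie within the scatter of each other, so neither compound stands apart from the other on the numbers so far.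

Compound 3, `COc1cc(/C=C/C(=O)c2cccc(-n3cc(-c4cc(OC)c(OC)c(OC)c4)[nH]c3=O)c2)cc(OC)c1OC`, has not yet been measured. It differs from compound 1 in one place: 3,4,5-trimethoxyphenyl in place of 4-chlorophenyl on an aromatic carbon. Among the compounds with values here, no pair of measured compounds differing in only one place is available, so the size of this step cannot be read from a measured example; the account relies on the two values alone. With compound 1 at 3850 nM and compound 2 at 3150 nM, both in the same range, the expectation is a step of a 1.3-fold lower number from compound 1 to compound 3 (0.11 log units; within the scatter), that is, no change beyond the scatter in either direction. Compound 3 is therefore estimated at 3000 nM in this assay, within a range from 1000 nM to 9000 nM.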

Compound 3, concentration for 50% growth inhibition: 1890 nM
Compound 3: the middle estimate sits 1.6-fold (0.20 log units) above what was measured; the measured number falls inside the stated range.
By their numbers in this assay, from the lowest: compounds 3, 2 and 1 (each within the scatter of the next, the first and the last beyond it).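

The step shows that this place on the five-membered aromatic ring, two ring bonds from the ring nitrogen, responds to a change made there alone: in this assay, 3,4,5-trimethoxyphenyl in place of 4-chlorophenyl gives a 2.0-fold lower number from compound 1 to compound 3 (0.31 log units; beyond the scatter), a modest change but one beyond the scatter. The earlier pair could not show this, since compound 1 and compound 2 differ in more than one place. The position also takes the larger 3,4,5-trimethoxyphenyl, with its 12 heavy atoms against 7 and its 3 hydrogen-bond acceptors against 0, without loss of growth inhibition, though no measurement at hand accounts for the step.

With a single step at this place, the compounds shown do not separate what the three methoxy groups contribute from what the removal of the chlorine contributes, and an unsubstituted phenyl or a 4-aminophenyl on the same core would be needed to tell these apart. They also leave open whether the step would keep its size if the 3,4,5-trimethoxyphenyl at the far end of the chalcone were replaced by another group, such as a 4-aminophenyl.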